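A few compounds are considered here, and "the series" means these few. Any claim that something is new, unique, unknown or untested is made for them only; others in the source may bear on it.

In a functional assay, read by spectrophotometry, with a stated time of 30 min, tested at 100 uM (a lower number here means a weaker effect, a higher number a stronger effect of the compound at the concentration tested), compound 1 `O=C(O)Cn1c(=O)c(/C=C/c2ccc(O)c(O)c2)nc2cc(Cl)cnc21` gives 97.1%, compound 2 `COc1ccc(-c2nc3cccnc3n(CC(=O)O)c2=O)cc1O` gives 32.1%, and compound 3 `COc1cc(CCc2nc3cccnc3n(CC(=O)O)c2=O)ccc1O` gives 40.1%. Compound 2 stands lowest of the three; its number and that of compound 3 lie within the usual scatter of each other, while the number of compound 1 lies well beyond it. Compound 4 `COc1c(O)cc(-c2nc3cccnc3n(CC(=O)O)c2=O)cc1O` has not yet been measured. It differs from compound 2 in one place: hydroxy in place of hydrogen on an aromatic carbon. For the measured compounds named here, no pair of measured compounds isolates such a change, so its size cannot be read from the numbers so far. A modest rise is expected, a step of a number 12.9 percentage points higher from compound 2 to compound 4 (beyond the scatter) in this assay. Compound 4 is expected to give about 45% in this assay, within a range from 20% to 75%.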

Compound 4, a percentage reported as activity, at one concentration (the size of the read-out at that concentration, not a potency): 45.6%
The estimate for compound 4 lay 0.6 percentage points below the measured number; measured number inside the range.
By their numbers in this assay, from the lowest: compounds 2, 3 and 4 (each within the scatter of the next, the first and the last beyond it); then compound 1.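

Hydroxy in place of hydrogen on an aromatic carbon, ortho to a methoxy group and meta to a hydroxy group, gives a number 13.5 percentage points higher from compound 2 to compound 4 (beyond the scatter) in this assay. This is the only step shown that isolates a change at this position, and it shows that the added hydroxy raises the read-out here, though only modestly. Nothing available explains the size of this step.

On these data alone, whether an amine or a fluorine atom at this position would give a similar step remains open. So does whether the same hydroxy would have a similar effect on the core of compound 1.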